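Two inactive pyrazoles and an untested ester analogue

This account rests on a few compounds, and the source may have more. Where it says the series, first, only, none or still open, it means among the compounds named here.

Measured in a functional assay on HL-60 cells (Homo sapiens) for cytotoxicity, read by MTT assay, with a stated time of 48 h; on this read-out lower numbers stand for stronger inhibition and higher numbers for weaker inhibition:
compound 1 `COc1ccc(OC(=O)c2cn(-c3ccccc3)nc2-c2cccnc2)cc1`: > 100000 nM
compound 2 `O=C(NCc1ccccc1)c1cn(-c2ccccc2)nc1-c1ccncc1`: > 100000 nM

In this assay compound 2 gives only a limit, not a number. Compound 1 likewise gives only a limit. Both results sit at the limit of > 100000 nM in this assay, at which 2 of the 2 values shown sit, so no order between the two can be drawn. Compound 3 `COc1ccc(OC(=O)c2cn(-c3ccccc3)nc2-c2ccncc2)cc1` differs from compound 2 by 4-methoxyphenoxy in place of benzylamino on a carbonyl carbon. Going by the values given here, no measured pair covers this change, and the expected step that the limit leaves unreadable from compound 2 to compound 3 is none beyond the scatter, with compound 3 expected to remain at the limit. Compound 3 is estimated at 150000 nM, within 50000 nM to 500000 nM.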

Compound 3, half-maximal inhibitory concentration: > 100000 nM
Compound 3 gave a limit, no number; the forecaster's own chance of this, stated with the estimate: 85%; the middle value lies beyond the limit too.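

Compound 1, compound 2 and compound 3 all give only a limit, so no step among them can be read: the limit of > 100000 nM in this assay, at which 3 of the 3 values shown sit.

The compounds shown leave open whether 4-methoxyphenoxy in place of benzylamino, or pyridin-4-yl in place of pyridin-3-yl, changes the result in this assay at all.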